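Replacing a dichlorophenyl with pyrimidinyl on a longer-linked core

A few compounds are considered here, and "the series" means these few. Any claim that something is new, unique, unknown or untested is made for them only; others in the source may bear on it.

The measured compounds and their values:
compound 1, `COc1ccc(/C=C2\NC(=O)N(CCCN3CCN(c4cccc(Cl)c4Cl)CC3)C2=O)cc1OC`, 22 nM;
compound 2, `COc1ccc(/C=C2\NC(=O)N(CCCN3CCN(c4ncccn4)CC3)C2=O)cc1OC`, 74 nM;
compound 3, `COc1ccc(/C=C2\NC(=O)N(CCCCN3CCN(c4cccc(Cl)c4Cl)CC3)C2=O)cc1OC1CCCC1`, 125 nM.

All three were tested in an assay on CHO cells for displacement of a labelled ligand from 5-hydroxytryptamine receptor 7 (Homo sapiens), read by scintillation counting, with a stated time of 60 min; on this read-out higher numbers stand for weaker inhibition and lower numbers for stronger inhibition. Compound 1 and compound 2 share one core and differ in a single place: pyrimidin-2-yl in place of 2,3-dichlorophenyl on an amine nitrogen in a ring. That change gave a 3.4-fold higher number from compound 1 to compound 2 (0.53 log units; beyond the scatter). Compound 3 has a different core from compound 1, and the difference between the two cores is not broken down here. Compound 3 has the highest number of the three, but its gap to compound 2 lies within the scatter, so the two cannot be ordered; only its gap to compound 1 lies beyond the scatter.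

The unmeasured compound 4, `COc1ccc(/C=C2\NC(=O)N(CCCCN3CCN(c4ncccn4)CC3)C2=O)cc1OC1CCCC1`, stands to compound 3 as compound 2 stands to compound 1: pyrimidin-2-yl in place of 2,3-dichlorophenyl on an amine nitrogen in a ring. For the measured compounds named here, the change is the same, at the same place, so the expectation for compound 4 rests on the one measured step, a 3.4-fold higher number from compound 1 to compound 2 (0.53 log units; beyond the scatter), carried over to the core of compound 3. On that basis the step from compound 3 to compound 4 is expected to be a 3.2-fold higher number from compound 3 to compound 4 (0.51 log units; beyond the scatter) in this assay. Going by the values given here, compound 4 is therefore estimated at 400 nM in this assay, with a likely range from 150 nM to 1200 nM, the range being wide because only one example of this change, a 3.4-fold higher number from compound 1 to compound 2 (0.53 log units; beyond the scatter), is available and on a different core.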

Compound 4, inhibition constant: 298 nM
Beside the measured number, compound 4's estimate is 1.3-fold (0.13 log units) above it; measured number inside the range.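

On the second core, in this assay, pyrimidin-2-yl in place of 2,3-dichlorophenyl on an amine nitrogen in a ring gave a 2.4-fold higher number from compound 3 to compound 4 (0.38 log units; beyond the scatter), in the same direction as on the first core. Set side by side, the two steps cannot be told apart: the same change on two cores in this assay, a 3.4-fold higher number (0.53 log units; beyond the scatter) from compound 1 to compound 2 and a 2.4-fold higher number (0.38 log units; beyond the scatter) from compound 3 to compound 4, 1.4-fold (0.15 log units) apart, within the scatter of two such steps. For the compounds shown here, this shows that, for these two cores, the change carried over with the same direction and a size that cannot be distinguished, but it rests on only two matched pairs and does not show that the change would behave the same way on any other core, nor does it explain why the number rises.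

The compounds shown leave open whether other groups at the same place, such as pyridin-2-yl or an unsubstituted phenyl, would fall in line with these two steps or depart from them. They also leave open how the separate differences between the two cores contribute, since the chain and the ether group change together, and a core with only one of these altered, or one with a longer chain, would be needed to separate them.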